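This account rests on a few compounds, and the source may have more. Where it says the series, first, only, none or still open, it means among the compounds named here.

Three compounds have been measured in an ADME assay on CHO cells (Cricetulus griseus) for inhibition, read by MTT assay; on this read-out higher numbers stand for weaker inhibition and lower numbers for stronger inhibition:

Compound 1 `CCN(CC)Cc1cccc(Nc2nc3ccccc3n2Cc2ccc(C#N)cc2)c1O` reaches only the limit, > 50000 nM.
Compound 2 `CCN(CC)Cc1ccc(Nc2nc3ccccc3[nH]2)cc1O` also reaches only the limit, > 50000 nM.
Compound 3 `CCN(CC)Cc1cccc(Nc2nc3ccccc3[nH]2)c1O` likewise reaches only the limit, > 50000 nM.

Compound 4 `CCN(CC)Cc1ccc(Nc2nc3ccccc3n2Cc2ccc(C#N)cc2)cc1O` has not yet been measured in this assay. It differs from compound 2 in one place: 4-cyanobenzyl in place of hydrogen on an aromatic nitrogen. The same change occurs from compound 3 to compound 1: 4-cyanobenzyl in place of hydrogen on an aromatic nitrogen. Its size there, a step that the two limits leave unreadable from compound 3 to compound 1, cannot be read, since both compounds stand at the limit of > 50000 nM in this assay, at which 3 of the 3 values shown sit. The difference between the cores of compound 2 and compound 3 is not broken down here.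

Compound 4 is expected to stay at the limit as well, because the limit of > 50000 nM in this assay, at which 3 of the 3 values shown sit, covers compound 1, compound 2 and compound 3 alike. This expectation means a step that the limit leaves unreadable from compound 2 to compound 4. Compound 4 is accordingly estimated at 100000 nM, with a range from 40000 nM to 300000 nM.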

Compound 4, half-maximal inhibitory concentration: 39000 nM
Estimate against measurement, compound 4: 2.6-fold (0.41 log units) above; the measured number lies below the stated range.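

In this assay, 4-cyanobenzyl on the aromatic nitrogen gives an at least 1.2-fold lower number from compound 2 to compound 4 (0.10 log units; that floor lies within the scatter), so on this core the change is not shown to exceed the scatter, although the true step could be larger. The same change from compound 3 to compound 1 cannot be read, as both compounds stand at a limit: the limit of > 50000 nM in this assay, at which 3 of the 4 values shown sit.

The two steps therefore cannot be compared, and the data show neither that the change carries from one core to the other nor that it does not. Going by these compounds, it remains open whether a plain benzyl on that aromatic nitrogen would give a number like that of compound 4. A carboxylic acid in place of the nitrile also remains untested among the compounds shown here.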